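This account rests on a few compounds, and the source may have more. Where it says the series, first, only, none or still open, it means among the compounds named here.

- compound 1 `C#CC[C@@H]1O[C@H](COCc2ccccc2)[C@@H](OCc2ccccc2)[C@H](OCc2ccccc2)[C@H]1O`: "not active" (no number reported)
- compound 2 `c1ccc(COC[C@H]2O[C@@H]3C[C@@H]3[C@@H](OCc3ccccc3)[C@@H]2OCc2ccccc2)cc1`: 38500 nM

In a functional assay on HL-60 cells (Homo sapiens) for antiproliferative activity, read by MTT assay (on this read-out lower numbers stand for stronger inhibition and higher numbers for weaker inhibition), compound 1 is reported as "not active" (no number reported), so it has no single number to start from. Going by the values given here, the only numerical reading comes from compound 2, at 38500 nM. Compound 3 `CCCC[C@@H]1O[C@H](COCc2ccccc2)[C@@H](OCc2ccccc2)[C@H](OCc2ccccc2)[C@H]1O` has not yet been measured. The structural change is propyl in place of ethynyl on a saturated chain carbon bound to a saturated ring carbon. Among the compounds with values here, no measured pair shows what such a change does in this assay. With compound 1 at "not active" (no number reported), no step beyond the scatter is expected, and the reading may again come back without a number. If a number is reported, the expected scale is that of compound 2 at 38500 nM. The estimate for compound 3 is 40000 nM, with an expected range from 15000 nM to 100000 nM.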

Compound 3, half-maximal inhibitory concentration: "not active" (no number reported)
No number was reported for compound 3; the estimate stays without a comparison.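

In this assay, going by these compounds alone, compound 1 gives "not active" (no number reported) and compound 3 gives "not active" (no number reported), so no step between them can be read. The compounds shown leave open whether propyl in place of ethynyl alters this activity at all. No evidence at hand bears on this result.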